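Amide variation in a paw-edema series

This account rests on a few compounds, and the source may have more. Where it says the series, first, only, none or still open, it means among the compounds named here.

Values in a functional assay on the whole organism (strain Wistar) for inhibition, with Rattus norvegicus as the target, read by paw edema, with stated times of 30 min and 3 h, at a dose of 100 mg/kg by the oral route; a higher number here means more inhibition at the dose given (going by the name of the read-out), a lower number less inhibition:
Compound 1 `CCCCOc1cc(C(=O)NCCC)nn1-c1ccccc1`: 51.2%
Compound 2 `CCCCOc1cc(C(=O)NC(C)C)nn1-c1ccccc1`: 15.8%
Compound 3 `CCCCOc1cc(C(=O)N2CCCC2)nn1-c1ccccc1`: 17.6%

Compound 3 stands second highest of the three numbers. Its nearest neighbour is within the scatter, a number 1.8 percentage points higher from compound 2 to compound 3 (within the scatter), whereas the one large gap in the set is a number 33.6 percentage points lower from compound 1 to compound 3 (beyond the scatter). For the measured compounds named here, the only other step, a number 35.4 percentage points lower from compound 1 to compound 2 (beyond the scatter), is likewise large and also runs from an unbranched propyl chain to a branched or ring-closed substituent.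

Compound 4 `CCCCOc1cc(C(=O)NCCCN(C)C)nn1-c1ccccc1` differs from compound 3 as follows: (3-(dimethylamino)propyl)amino in place of pyrrolidin-1-yl on a carbonyl carbon. The step that bears on this is a number 33.6 percentage points lower from compound 1 to compound 3 (beyond the scatter), taken in reverse: the ring opens again to a chain attached through an amide-type nitrogen, as in compound 1. Going by the values given here, no measured step covers the dimethylamino end of the chain, so the size of the return is uncertain. A rise beyond the scatter is expected for compound 4 due to a number 33.6 percentage points lower from compound 1 to compound 3 (beyond the scatter), roughly a number 22.4 percentage points higher from compound 3 to compound 4 (beyond the scatter). Compound 4 is therefore estimated at 40%, within a range of 15% to 62%.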

Compound 4, a percentage reported as inhibition, in the whole organism at one dose (the size of the read-out at that dose, not a potency): 29.8%
The estimate for compound 4 lay 10.2 percentage points above the measured number; measured number inside the range.
By their numbers in this assay, from the lowest: compounds 2 and 3 (each within the scatter of the next); then compound 4; then compound 1.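

In this assay, the open chain on the carbonyl carbon gives a partial return, with a number 12.2 percentage points higher from compound 3 to compound 4 (beyond the scatter) and a number 14 percentage points higher from compound 2 to compound 4 (beyond the scatter). For the compounds shown here, the return stops short of the propyl amide, with a number 21.4 percentage points lower from compound 1 to compound 4 (beyond the scatter), so an unbranched chain at this position is not enough on its own to hold the level of compound 1, and the dimethylamino end marks the one place where compound 4 departs from compound 1. No measurement available here accounts for these steps.

The compounds shown leave open whether the lower number of compound 4 goes with the terminal dimethylamino group or with the longer chain that carries it. A plain pentyl chain on the amide nitrogen, or a morpholine at the end of the propyl chain, would help separate the two.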